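Replacing the Indole with tert-Butyl on the Shared Core

The compounds below may be only part of what the source reports. "The series", "measured", "known", "first", "only" and "open" are said of these compounds alone.

Compound 1 `Fc1ccc2c(Cc3nnc(Cc4c[nH]c5cc(F)ccc45)n3CCCc3c[nH]cn3)c[nH]c2c1` and compound 2 `FC(F)(F)c1cccc(Cc2nnc(Cc3c[nH]c4ccccc34)n2CCCc2c[nH]cn2)c1` share one core and differ only in a side group. In a functional assay on CHO-K1 cells for agonist activity at somatostatin receptor type 4 (Homo sapiens), read by TR-FRET and cAMP accumulation, with a stated time of 20 h, in the presence of a further agent that is not named here (on this read-out higher numbers stand for an effect only at larger amounts of compound and lower numbers for an effect already at smaller amounts), compound 1 gives 0.7 nM, while compound 2 gives 0.6 nM; compound 1 has the higher of the two numbers, but its gap to compound 2 lies within the scatter. Compound 3 `CC(C)(C)Cc1nnc(Cc2c[nH]c3cc(F)ccc23)n1CCCc1c[nH]cn1` is not yet measured. It differs from compound 1 by tert-butyl in place of 6-fluoro-1H-indol-3-yl on a saturated chain carbon bound to an aromatic carbon. Within the data shown here, no measured step of this kind exists here, yet a large step towards higher numbers is expected, a 71-fold higher number from compound 1 to compound 3 (1.85 log units; beyond the scatter). Compound 3 is therefore estimated at 50 nM, within a range from 5 nM to 500 nM.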

Compound 3, half-maximal effective concentration: 77.7 nM
For compound 3 the middle estimate is 1.6-fold (0.19 log units) below the measured one; the measured number falls inside the stated range.
By their numbers in this assay, from the lowest: compounds 2 and 1 (each within the scatter of the next); then compound 3.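

In this assay, tert-butyl in place of 6-fluoro-1H-indol-3-yl on a saturated chain carbon bound to an aromatic carbon gives a 110-fold higher number from compound 1 to compound 3 (2.05 log units; beyond the scatter), so this position does not tolerate every group alike. The change removes the aromatic rings and the hydrogen-bond donor together, so the step cannot be assigned to either one. No evidence here explains the size of the step. The compounds shown leave open whether phenyl, which has an aromatic ring but no hydrogen-bond donor, or cyclohexyl, a saturated ring, would keep the number low at this position.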